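This account rests on a few compounds, and the source may have more. Where it says the series, first, only, none or still open, it means among the compounds named here.

Measured compounds:
compound 1 `CCN1CCCC[C@H]1[C@H]1COC(c2ccccc2)(c2ccccc2)O1` 6900 nM
compound 2 `C=CCN1CCCC[C@H]1[C@H]1COC(c2ccccc2)(c2ccccc2)O1` 15200 nM
compound 3 `c1ccc(CN2CCCC[C@H]2[C@H]2COC(c3ccccc3)(c3ccccc3)O2)cc1` 10100 nM

In a functional assay (brain) for displacement of a labelled ligand, with Rattus norvegicus as the target (a lower number here means a stronger inhibitor, a higher number a weaker inhibitor), compound 1 gives the lowest of the three numbers; its step to compound 3 is a 1.5-fold higher number from compound 1 to compound 3 (0.17 log units; within the scatter), and its step to compound 2 is a 2.2-fold higher number from compound 1 to compound 2 (0.34 log units; beyond the scatter). Compound 4 `C[C@H](N)[C@H]1COC(c2ccccc2)(c2ccccc2)O1` differs from compound 1 by 1-aminoethyl in place of 1-ethylpiperidin-2-yl on a saturated ring carbon. Among the measured compounds shown here, the measured steps all change only the group on the amine nitrogen in the ring, and none of them removes the ring itself, so no measured step bears directly on this change. With all three numbers lying in the same weak range, a modest rise, or no step beyond the scatter, is expected: a 1.7-fold higher number from compound 1 to compound 4 (0.24 log units; within the scatter). Compound 4 is therefore estimated at 12000 nM, with a wide range from 2500 nM to 60000 nM.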

Compound 4, inhibition constant: 607 nM
Compound 4: middle estimate off by 20-fold (1.30 log units), on the high side, and the stated range ends above it.
By their numbers in this assay, from the lowest: compound 4; then compounds 1, 3 and 2 (each within the scatter of the next, the first and the last beyond it).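

In this assay, replacing 1-ethylpiperidin-2-yl with 1-aminoethyl on this saturated ring carbon gives an 11-fold lower number from compound 1 to compound 4 (1.06 log units; beyond the scatter), so the number responds far more strongly here than to the earlier changes of the group on the ring nitrogen. The six-membered ring is therefore not needed for activity in this series. However, this single change removes the ring and the ethyl group, and adds a hydrogen-bond donor, so these contributions cannot be separated.

Going by these compounds, it remains open whether 1-aminopropyl, aminomethyl or an ethyl group on the nitrogen of 1-aminoethyl would preserve this gain. No measurement shown explains the gain.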